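The compounds below may be only part of what the source reports. "The series", "measured", "known", "first", "only" and "open" are said of these compounds alone.

Compound 1: `O=C(NCc1ccc(S(=O)(=O)c2cc(F)cc(F)c2)cc1)N1Cc2ccncc2C1` — 8 mL/min/kg
Compound 2: `O=C(NCc1ccc(S(=O)(=O)C2CCN(C3COC3)CC2)cc1)N1Cc2ccncc2C1` — 10 mL/min/kg

Both numbers come from an ADME assay on microsomes from liver (Homo sapiens) for pharmacokinetics, read by LC-MS, with a stated time of 60 min, tested at 1 uM; a lower number here means slower removal, a higher number faster removal of the compound. Compound 2 stands alongside compound 1: the step of a 1.3-fold higher number from compound 1 to compound 2 (0.10 log units; within the scatter) is the only measured one here, and it falls within the scatter, so the two compounds cannot be told apart on these numbers.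

Compound 3 is `O=C(NCc1ccc(S(=O)(=O)N2CC3(CCOCC3)C2)cc1)N1Cc2ccncc2C1`. It differs from compound 2 in one place: a group of 9 heavy atoms (7 carbon, 1 nitrogen, 1 oxygen; one four-membered non-aromatic ring with 1 hetero atom, one six-membered non-aromatic ring with 1 hetero atom) in place of a group of 10 heavy atoms (8 carbon, 1 nitrogen, 1 oxygen; one four-membered non-aromatic ring with 1 hetero atom, one six-membered non-aromatic ring with 1 hetero atom), on a sulfonyl sulfur

Going by the values given here, the one measured step that bears on this change is the same kind of swap, a new group on the sulfonyl sulfur, and it moved the number only as much as a 1.3-fold higher number from compound 1 to compound 2 (0.10 log units; within the scatter). With nothing else to go on, a step of similar size is expected here, with no clear direction beyond the scatter. The expected step for compound 3 is therefore no change at the digits printed from compound 2 to compound 3 (within the scatter). In this assay compound 3 is estimated at 10 mL/min/kg, with a range from 5 mL/min/kg to 20 mL/min/kg.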

Compound 3, clearance: 13 mL/min/kg
Beside the measured number, compound 3's estimate is 1.3-fold (0.11 log units) below it; the measured number falls inside the stated range.
By their numbers in this assay, from the lowest: compounds 1, 2 and 3 (each within the scatter of the next).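

In this assay, a third kind of group on the sulfonyl sulfur again gives no separation: the data show a 1.3-fold higher number from compound 2 to compound 3 (0.11 log units; within the scatter) and also a 1.6-fold higher number from compound 1 to compound 3 (0.21 log units; within the scatter). This position has now carried 3,5-difluorophenyl, 1-(oxetan-3-yl)piperidin-4-yl and a group joined to the sulfur through a ring nitrogen rather than a carbon, and that change of attaching atom, new with compound 3, gives no step beyond the scatter. Nothing available explains why these three groups read alike.

From the compounds shown here alone, it remains open whether any group at this sulfonyl sulfur can move the clearance beyond the scatter, for example a simple methyl, or a ring carrying a carboxylic acid or a primary amine. The compounds shown also all share one core, so they leave open whether the same insensitivity to the sulfonyl group would hold if another part of the molecule were changed.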